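Replacing a 3-bromobenzyl group with propyl

This account rests on a few compounds, and the source may have more. Where it says the series, first, only, none or still open, it means among the compounds named here.

Compound 1 `Cc1cc(Nc2ccn(Cc3ccccc3)n2)n2nc(SCc3ccc(Br)cc3)nc2n1` gives a value in a functional assay on PC-9 cells (Homo sapiens) for inhibition, read by MTT assay, with a stated time of 72 h (a higher number here means a weaker inhibitor, a lower number a stronger inhibitor), that is only a limit of the assay: > 50000 nM. Compound 2 `Cc1cc(Nc2cc(-c3ccccc3)[nH]n2)n2nc(SCc3cccc(Br)c3)nc2n1` gives 8900 nM in this assay. Compound 3 `Cc1cc(Nc2cc(-c3ccc(Cl)cc3)[nH]n2)n2nc(SCc3ccc(Br)cc3)nc2n1` gives 4920 nM in this assay.

Among the two values that are numbers rather than limits, compound 2 holds the higher one, but the gap to compound 3 falls within the usual scatter of this assay, so the two cannot be placed in order. Compound 4 `CCCSc1nc2nc(C)cc(Nc3cc(-c4ccccc4)[nH]n3)n2n1` differs from compound 2 in one place: ethyl in place of 3-bromophenyl on a saturated chain carbon bound to a sulfur. For the measured compounds named here, no measured pair in this set isolates this change, so the size of its effect in this assay has no direct precedent here. Going by the values given here, the three measured compounds all carry a ring on the carbon bound to the sulfur, and the only compound sitting at the limit, compound 1, is also the only one without a hydrogen on the pyrazole nitrogen, which compound 4 keeps. The loss of the ring is expected to weaken inhibition in this assay, with a step from compound 2 to compound 4 estimated at a 2.8-fold higher number from compound 2 to compound 4 (0.45 log units; beyond the scatter). Compound 4 is therefore estimated at 25000 nM, within a range from 7000 nM to 80000 nM.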

Compound 4, half-maximal inhibitory concentration: > 50000 nM
Compound 4 gave a limit, no number; the forecaster's own chance of this, stated with the estimate: 35%; at least 2.0-fold (0.30 log units) between middle value and limit.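

For the compounds shown here, this pair gives the first direct reading at this position: in this assay, ethyl in place of 3-bromophenyl on a saturated chain carbon bound to a sulfur gives an at least 5.6-fold higher number from compound 2 to compound 4 (0.74 log units; beyond the scatter). The 3-bromobenzyl group therefore cannot be cut back to propyl in this series without a loss of inhibition beyond the scatter. The full size of the loss remains unknown, because compound 4 gives a limit and not a number: the limit of > 50000 nM in this assay, at which 2 of the 4 values shown sit.

The change removes the ring and the bromine together, and the compounds shown do not separate the two. Going by these compounds, it remains open whether a plain benzyl group, a longer chain such as hexyl, or a chain ending in an amine would bring the value back from the limit.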